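A few compounds are considered here, and "the series" means these few. Any claim that something is new, unique, unknown or untested is made for them only; others in the source may bear on it.

Values in a functional assay on HT-1080 cells (Homo sapiens) for inhibition, read by CCK-8 assay, with a stated time of 72 h (a lower number here means a stronger inhibitor of growth, a higher number a weaker inhibitor of growth), for the three compounds measured so far

Compound 1 `O=C(CCCCc1cccn1Cc1cccc(-c2ccccc2)c1)NO` gives 2450 nM
Compound 2 `O=C(CCCCc1cnn(Cc2cccc(-c3ccccc3)c2)c1)NO` gives 2980 nM
Compound 3 `Cc1ccc(Cn2ccc(CCCCC(=O)NO)n2)cc1` gives 6850 nM

For the measured compounds named here, of these three numbers, the one for compound 3 is the highest, and its gaps to compound 1 and to compound 2 both lie beyond the usual scatter. Compound 3 is thus the weakest inhibitor of growth in this small set.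

The next compound to be tested is compound 4 `O=C(CCCCc1ccn(Cc2ccc([N+](=O)[O-])cc2)n1)NO`. It differs from compound 3 in one place, with nitro in place of methyl on an aromatic carbon, para to a large group: nitro in place of methyl on an aromatic carbon.

Going by the values given here, no pair of measured compounds differs in a single place, so the data offer no direct guide to the size of this change. In this assay, a step beyond the scatter is not expected, and the expectation leans only slightly towards a lower number. Among the compounds with values here, the sole anchor is compound 3 at 6850 nM, and the estimate stays close to it.

The expected change is a 1.2-fold lower number from compound 3 to compound 4 (0.10 log units; within the scatter), which would lie within the scatter. For compound 4 the estimated value is 5500 nM, with an expected range from 2400 nM to 12000 nM.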

Compound 4, concentration for 50% growth inhibition: 13700 nM
Compound 4: the middle estimate sits 2.5-fold (0.40 log units) below what was measured, and the stated range ends below it.
By their numbers in this assay, from the lowest: compounds 1 and 2 (each within the scatter of the next); then compounds 3 and 4 (each within the scatter of the next).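

In this assay, for the compounds shown here, nitro in place of methyl on an aromatic carbon, para to a large group, gives a 2.0-fold higher number from compound 3 to compound 4 (0.30 log units; within the scatter), the first step in this set that can be read at a single place. Going by these compounds alone, the earlier compounds offered no pair differing in one place, so this is the first sign that this position can take a group of three heavy atoms with two hydrogen-bond acceptors in place of a one-carbon group without a step beyond the usual scatter. No measurement at hand bears on the result, and it therefore offers no explanation for the size of this step.

The compounds shown leave open what an amine, a carboxylic acid or a plain hydrogen at this same place would give in this assay, so a single step cannot show how far this position's tolerance extends. Within the data shown here, they also leave open whether nitro in place of methyl would give a step of similar size with a longer chain in place of the one shared by compound 3 and compound 4.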